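Compound 4: a pyridin-4-yl ether in a dichloropyridine amide series

The compounds below may be only part of what the source reports. "The series", "measured", "known", "first", "only" and "open" are said of these compounds alone.

Measured compounds:
compound 1 `CCO/N=C(/c1ccc(Br)cc1)C1CCN(C(C)CCNC(=O)c2c(Cl)cncc2Cl)CC1`: 33800 nM
compound 2 `CC(CCNC(=O)c1c(Cl)cncc1Cl)N1CCC(C(=O)c2ccc(Br)cc2)CC1`: 189000 nM
compound 3 `CC(CCNC(=O)c1c(Cl)cncc1Cl)N1CCC(C(O)c2ccc(Br)cc2)CC1`: 198000 nM

Compound 3 `CC(CCNC(=O)c1c(Cl)cncc1Cl)N1CCC(C(O)c2ccc(Br)cc2)CC1` gives 198000 nM in an ADME assay on PBMC cells (Homo sapiens) for cytotoxicity (a lower number here means that less compound is tolerated, a higher number that more compound is tolerated), the highest of the three numbers. Compound 2 is nearest: a 1.0-fold higher number from compound 2 to compound 3 (0.02 log units; within the scatter). Compound 1, with its ethoxyimino group, gives 33800 nM, the lowest of the three.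

Compound 4 `CC(CCNC(=O)c1c(Cl)cncc1Cl)N1CCC(C(Oc2ccncc2)c2ccc(Br)cc2)CC1` is the next compound. It differs from compound 3 in one place: pyridin-4-yl in place of hydrogen on an oxygen on a saturated carbon. Among the measured compounds shown here, no measured step changes the substituent on this oxygen, so there is no direct precedent. For the measured compounds named here, the only single step known, a 1.0-fold higher number from compound 2 to compound 3 (0.02 log units; within the scatter), touched the same saturated carbon and stayed within the scatter. Compound 1, which carries an ethyl on an oxygen at the corresponding position, lies well below compound 3, but that pair differs in more than one place, so its gap offers only a loose hint that a larger group on this oxygen may lower the tolerated amount.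

Compound 4 is therefore expected to show a 2.0-fold lower number from compound 3 to compound 4 (0.30 log units; within the scatter), a modest downward step, with an estimated 100000 nM and a range from 30000 nM to 250000 nM.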

Compound 4, half-maximal cytotoxic concentration: 31200 nM
For compound 4 the middle estimate is 3.2-fold (0.51 log units) above the measured one, within the range that was stated.
By their numbers in this assay, from the lowest: compounds 4 and 1 (each within the scatter of the next); then compounds 2 and 3 (each within the scatter of the next).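

In this assay, among the compounds shown here, replacing the hydroxy hydrogen with pyridin-4-yl gives a 6.3-fold lower number from compound 3 to compound 4 (0.80 log units; beyond the scatter), the first step to lie beyond the scatter. The earlier change at the same saturated carbon, a 1.0-fold higher number from compound 2 to compound 3 (0.02 log units; within the scatter), lay within the scatter, so this position did not respond to exchanging carbonyl for hydroxy but does respond to hydroxy becoming (pyridin-4-yl)oxy. No measurement on hand accounts for the lower number.

The compounds shown leave open whether this step depends on the pyridine ring with its nitrogen or would follow from any substituent on this oxygen. A phenyl or a methyl on the same oxygen would separate these readings, and an amine in place of the oxygen would show whether the ether link itself matters.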